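Clearance notes: substituent change at the aromatic carbon

The compounds below may be only part of what the source reports. "The series", "measured", "known", "first", "only" and "open" are said of these compounds alone.

Measured so far in an ADME assay (liver) for metabolic stability, with Liver microsome (Homo sapiens) as the target, using microsomes and NADPH, with a stated time of 30 min, tested at 1 uM; on this read-out lower numbers stand for slow clearance and higher numbers for fast clearance:
- compound 1 `Nc1ccc(S(=O)(=O)N2CCN(c3ncc(C(O)(C(F)(F)F)C(F)(F)F)cc3C3CC3)CC2)cn1` gives 38 mL.min-1.g-1.
- compound 2 `COCC#Cc1cc(C(O)(C(F)(F)F)C(F)(F)F)cnc1N1CCN(S(=O)(=O)c2ccc(N)nc2)CC1` gives 15 mL.min-1.g-1.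
- compound 3 `CC(C)(O)C#Cc1cc(C(O)(C(F)(F)F)C(F)(F)F)cnc1N1CCN(S(=O)(=O)c2ccc(N)nc2)CC1` reaches only a limit of the assay, < 14 mL.min-1.g-1.

Compound 2 holds the lowest of the two numbers; compound 1 sits higher by a 2.5-fold lower number from compound 1 to compound 2 (0.40 log units; beyond the scatter). Compound 3 sits at the assay floor (the limit of < 14 mL.min-1.g-1 in this assay, at which 1 of the 3 values shown sits), so the step of an at least 1.0-fold lower number from compound 2 to compound 3 (0.02 log units; that floor lies within the scatter) cannot be placed beyond the scatter, and no order between compound 2 and compound 3 is claimed.

The next compound, compound 4 `Nc1ccc(S(=O)(=O)N2CCN(c3ncc(C(O)(C(F)(F)F)C(F)(F)F)cc3-c3ccccc3O)CC2)cn1`, differs from compound 2 by 2-hydroxyphenyl in place of 3-methoxyprop-1-yn-1-yl on an aromatic carbon.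

Among the measured compounds shown here, the steps that bear on this position are a 2.5-fold lower number from compound 1 to compound 2 (0.40 log units; beyond the scatter) and an at least 2.7-fold lower number from compound 1 to compound 3 (0.43 log units; beyond the scatter), both modest and both replacing cyclopropyl with an alkyne; no measured step exchanges an alkyne for an aromatic ring, so the direction is uncertain. The change from compound 2 to compound 4 is expected to give no more than a modest step, a 1.5-fold higher number from compound 2 to compound 4 (0.17 log units; within the scatter). Compound 4 is therefore estimated at 22 mL.min-1.g-1, with a range from 11 mL.min-1.g-1 to 45 mL.min-1.g-1.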

Compound 4, intrinsic clearance in microsomes: 22 mL.min-1.g-1
Beside the measured number, compound 4's estimate shows no gap at the digits printed; the measured number falls inside the stated range.
By their numbers in this assay, from the lowest: compounds 2, 4 and 1 (each within the scatter of the next, the first and the last beyond it). At a limit, below all of these: compound 3.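

In this assay, 2-hydroxyphenyl in place of 3-methoxyprop-1-yn-1-yl gives a 1.5-fold higher number from compound 2 to compound 4 (0.17 log units; within the scatter). Against the cyclopropyl group the same ring gives a 1.7-fold lower number from compound 1 to compound 4 (0.24 log units; within the scatter), so compound 4 cannot be separated from either compound, although the step from compound 1 to compound 2 lies beyond the scatter. Compound 3 stands at a limit of the assay. The step of an at least 1.5-fold higher number from compound 3 to compound 4 (0.19 log units; that floor lies within the scatter) therefore cannot be read: the limit of < 14 mL.min-1.g-1 in this assay, at which 1 of the 4 values shown sits.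

Going by these compounds, what the hydroxyl of 2-hydroxyphenyl contributes stays open, and a plain phenyl at this place would separate it from the ring itself. An amine or a carboxylic acid on the ring would show whether clearance at this position moves beyond the scatter with an aromatic group in place.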